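The source may report more compounds than this note shows. Statements on the series, on what has been measured and on what is new or still open speak of the compounds shown alone.

Working notes on the series. Compound 3 `Cc1cc(Nc2ccc(F)cc2)n(-c2nc(C(F)(F)F)cc(=O)[nH]2)n1` carries the lowest number of the three compounds tested in an ADME assay on CHO cells (Cricetulus griseus) for cytotoxicity, read by MTT assay (a lower number here means a stronger inhibitor, a higher number a weaker inhibitor), where compound 3 gives 20000 nM; compound 1 `CCc1cc(C)nn1-c1nc(C(F)(F)F)cc(=O)[nH]1` gives 108000 nM and compound 2 `Cc1cc(C2CC2)n(-c2nc(C(F)(F)F)cc(=O)[nH]2)n1` gives 78000 nM. Compound 4 `Cc1cc(Nc2ccccn2)n(-c2nc(C(F)(F)F)cc(=O)[nH]2)n1` differs from compound 3 by pyridin-2-yl in place of 4-fluorophenyl on a nitrogen on an aromatic ring. Among the measured compounds shown here, no measured step exchanges one ring for another on this nitrogen. The steps that touch the same position, a 5.4-fold lower number from compound 1 to compound 3 (0.73 log units; beyond the scatter) and a 3.9-fold lower number from compound 2 to compound 3 (0.59 log units; beyond the scatter), are modest, while a 1.4-fold lower number from compound 1 to compound 2 (0.14 log units; within the scatter) is within the scatter. With the arylamino substituent retained, compound 4 is expected to stay close to compound 3, with a 1.3-fold higher number from compound 3 to compound 4 (0.10 log units; within the scatter) not beyond the scatter. Compound 4 is therefore estimated at 25000 nM, between 10000 nM and 60000 nM.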

Compound 4, half-maximal inhibitory concentration: 23000 nM
For compound 4 the middle estimate is 1.1-fold (0.04 log units) above the measured one, and the stated range covers the measured number.
By their numbers in this assay, from the lowest: compounds 3 and 4 (each within the scatter of the next); then compounds 2 and 1 (each within the scatter of the next).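

Among the compounds shown here, compound 4 brings the first ring-for-ring exchange on this nitrogen in this assay, and a 1.2-fold higher number from compound 3 to compound 4 (0.06 log units; within the scatter) shows that pyridin-2-yl and 4-fluorophenyl cannot be told apart here. The separation from the carbon-linked groups survives the exchange, with a 3.4-fold lower number from compound 2 to compound 4 (0.53 log units; beyond the scatter) and a 4.7-fold lower number from compound 1 to compound 4 (0.67 log units; beyond the scatter), both modest, so in these compounds it is not tied to 4-fluorophenyl. No supporting data bear on this result.

Still open, as far as these compounds go, is how much of the separation belongs to the amino nitrogen and how much to the ring on it. A plain amino group, or a morpholine in place of the arylamino group, would address this.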